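The source may report more compounds than this note shows. Statements on the series, on what has been measured and on what is new or still open speak of the compounds shown alone.

Compounds measured so far:
- Compound 1 `COc1ccc(-c2cc([C@@H]3O[C@H](CO)[C@@H](O)[C@H]3O)n3ncnc(N)c23)cc1`: 62600 nM
- Compound 2 `Nc1ncnn2c([C@@H]3O[C@H](CO)[C@@H](O)[C@H]3O)cc(/C=C/c3ccccc3)c12`: 1300 nM

In a functional assay on Z-138 cells (Homo sapiens) for antiproliferative activity, with a stated time of 72 h (a higher number here means a weaker inhibitor, a lower number a stronger inhibitor), compound 2 stands lowest of the two numbers at 1300 nM, which makes it the stronger inhibitor of the pair. The next compound, compound 3 `Nc1ncnn2c([C@@H]3O[C@H](CO)[C@@H](O)[C@H]3O)cc(-c3ccccc3Cl)c12`, has not yet been measured. It carries 2-chlorophenyl in place of 2-phenylethenyl on an aromatic carbon of the shared core (2-chlorophenyl in place of 2-phenylethenyl on an aromatic carbon).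

Within the data shown here, only one measured step bears on this change: a 48-fold lower number from compound 1 to compound 2 (1.68 log units; beyond the scatter), a large step beyond the scatter, made by 2-phenylethenyl replacing 4-methoxyphenyl at the same place. Like compound 3, compound 1 has a substituted phenyl group there and gives 62600 nM. A move back towards the weaker end in this assay is therefore expected. Among the measured compounds shown here, the two phenyl groups differ, however, and no measured compound carries chlorine, so only part of that step is expected to be undone. The expected change is a 7.7-fold higher number from compound 2 to compound 3 (0.89 log units; beyond the scatter). For compound 3 the estimated value is 10000 nM, with an expected range of 2500 nM to 40000 nM.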

Compound 3, half-maximal inhibitory concentration: 76100 nM
For compound 3 the middle estimate is 7.6-fold (0.88 log units) below the measured one; the whole stated range lies below it.
By their numbers in this assay, from the lowest: compound 2; then compounds 1 and 3 (each within the scatter of the next).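

In this assay, 2-chlorophenyl in place of 2-phenylethenyl on this aromatic carbon gives a 59-fold higher number from compound 2 to compound 3 (1.77 log units; beyond the scatter), so the full gain seen with 2-phenylethenyl is lost, not just part of it. Replacing 4-methoxyphenyl with 2-chlorophenyl gives a 1.2-fold higher number from compound 1 to compound 3 (0.08 log units; within the scatter), which shows that these two differently substituted phenyl groups cannot be told apart in this assay; among the three compounds, only the 2-phenylethenyl group of compound 2 stands apart from the rest. Nothing available explains why this position responds in this way.

The compounds shown leave open whether the low number of compound 2 depends on the double bond itself or on the chain that carries the phenyl ring, a question that a saturated 2-phenylethyl chain at this place would address. They also leave open whether a plain unsubstituted phenyl group, or a 2-phenylethenyl group bearing a chlorine or methoxy substituent on its ring, would sit with compound 2 or with compound 1 and compound 3.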